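Chloro in Place of Methoxy: From Compound 3 to Compound 4

This account rests on a few compounds, and the source may have more. Where it says the series, first, only, none or still open, it means among the compounds named here.

Four compounds share one core and differ only in the group on the six-membered aromatic ring of carbon only. Compound 1 `O=C(/C=C/c1ccc2c(ccc[n+]2[O-])c1)c1ccc(F)cc1` carries fluoro, and in a functional assay on HL-60 cells (Homo sapiens) for antiproliferative activity, read by MTT assay, with a stated time of 48 h (on this read-out higher numbers stand for weaker inhibition and lower numbers for stronger inhibition), compound 1 is reported as "not active" (no number reported). Compound 2 `Cc1ccc(C(=O)/C=C/c2ccc3c(ccc[n+]3[O-])c2)cc1` carries methyl, and in this assay compound 2 gives 20.3 ug/mL. Compound 3 `COc1ccc(C(=O)/C=C/c2ccc3c(ccc[n+]3[O-])c2)cc1` carries methoxy, and in this assay compound 3 gives 14.8 ug/mL, the lowest of the two numbers, though the step of a 1.4-fold lower number from compound 2 to compound 3 (0.14 log units; within the scatter) lies within the scatter, so compound 3 and compound 2 cannot be told apart on these data.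

Compound 4 `O=C(/C=C/c1ccc2c(ccc[n+]2[O-])c1)c1ccc(Cl)cc1` differs from compound 3 by chloro in place of methoxy on an aromatic carbon. Within the data shown here, only one measured step bears on this change, a 1.4-fold lower number from compound 2 to compound 3 (0.14 log units; within the scatter), and it was small. Compound 1, the other halogen-bearing member, returned "not active" (no number reported), a warning that a halogen here may again yield no number. Weighing the small methyl-to-methoxy step against that outcome, compound 4 is expected to show a modest upward step, a 1.5-fold higher number from compound 3 to compound 4 (0.17 log units; within the scatter). Compound 4 is therefore estimated at 22 ug/mL, with a range from 9 ug/mL to 55 ug/mL.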

Compound 4, half-maximal inhibitory concentration: 33.8 ug/mL
Compound 4: the middle estimate sits 1.5-fold (0.19 log units) below what was measured; the measured number falls inside the stated range.
By their numbers in this assay, from the lowest: compounds 3, 2 and 4 (each within the scatter of the next, the first and the last beyond it).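

In this assay, among these compounds, the step of a 2.3-fold higher number from compound 3 to compound 4 (0.36 log units; beyond the scatter) is the first at this position to lie beyond the scatter, which shows that chloro in place of methoxy, para to a large group, can be told apart on these data, while the step of a 1.7-fold higher number from compound 2 to compound 4 (0.22 log units; within the scatter) stays within the scatter, so chloro and methyl cannot be separated. The chloro compound also yields a number, whereas the fluoro-bearing compound 1 gives "not active" (no number reported), so a halogen at this position does not always end without a number. Nothing shown here accounts for the size of either step or for the difference between the two halogens.

The compounds shown leave open how an amine, a hydroxyl, a carboxylic acid or a longer chain such as ethoxy would read at this position in this assay. They also leave open whether bromo would follow chloro in giving a number or fluoro in giving none, and whether the gap between methoxy and chloro would persist on a different core.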